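A few compounds are considered here, and "the series" means these few. Any claim that something is new, unique, unknown or untested is made for them only; others in the source may bear on it.

Going by the values given here, compound 2 `Nc1cc(N)c2nc(-c3ccccc3)c(NCc3ccc(F)cc3)nc2c1` gives the lowest of the two numbers so far measured in a functional assay on U-251 cells (Homo sapiens) for inhibition, read by sulforhodamine B assay, with a stated time of 48 h (on this read-out higher numbers stand for lower toxicity in this test and lower numbers for higher toxicity in this test), at 6310 nM, while compound 1 `COc1ccc(CNc2nc3cc(N)cc(N)c3nc2-c2ccccc2)cc1OC` gives 89100 nM. Compound 3 `COc1ccc(CNc2nc3cc(N)cc(N)c3nc2-c2ccccc2)cc1` differs from compound 2 by methoxy in place of fluoro on an aromatic carbon. Among the compounds with values here, the only measured step bearing on this change is a 14-fold lower number from compound 1 to compound 2 (1.15 log units; beyond the scatter), in which the 3,4-dimethoxyphenyl gave way to the 4-fluorophenyl. Restoring a single methoxy is expected to carry the number part of the way back toward compound 1, so a step of a 3.2-fold higher number from compound 2 to compound 3 (0.50 log units; beyond the scatter) is expected. Compound 3 is accordingly estimated at 20000 nM, with a range from 6000 nM to 60000 nM.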

Compound 3, concentration lethal to 50% of the cells: 51300 nM
Compound 3: middle estimate off by 2.6-fold (0.41 log units), on the low side; the range from low to high includes it.
By their numbers in this assay, from the lowest: compound 2; then compounds 3 and 1 (each within the scatter of the next).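

In this assay, methoxy in place of fluoro on an aromatic carbon alone gives an 8.1-fold higher number from compound 2 to compound 3 (0.91 log units; beyond the scatter) and so accounts for most of the earlier gap. Removing the other methoxy gives a 1.7-fold lower number from compound 1 to compound 3 (0.24 log units; within the scatter) and leaves compound 3 and compound 1 indistinguishable, so that methoxy has no readable effect here. No measured evidence bears on the cause of this result.

The compounds shown leave open whether the low number is particular to fluoro or would also appear with chloro, methyl or plain hydrogen on this carbon.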